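Working notes on the shared core series

The source may hold more compounds than are shown below. What is called first, only, known or untested is meant among the compounds shown, and "the series" means these compounds.

The shared core is held constant; the compounds differ only in the group on a saturated chain carbon bound to an amine nitrogen in a ring. Compound 1 `COc1cc(N)c(Cl)cc1NC(=O)C1CCN(C/C=C/c2ccccc2)CC1` carries 2-phenylethenyl there. In a functional assay on the whole organism for antagonist activity, with Mus musculus as the target (a higher number here means that more compound is needed for the effect, a lower number that less compound is needed), compound 1 gives only a limit, > 10 mg/kg. Compound 2 `COc1cc(N)c(Cl)cc1NC(=O)C1CCN(CC2CCC2)CC1` carries cyclobutyl instead. In this assay compound 2 likewise gives only a limit, > 10 mg/kg. Compound 3 `COc1cc(N)c(Cl)cc1NC(=O)C1CCN(Cc2ccc(O)cc2)CC1` carries 4-hydroxyphenyl. In this assay compound 3 gives only a limit, > 8 mg/kg. Compound 3 therefore stands nowhere that can be ranked: a step that the two limits leave unreadable from compound 1 to compound 3 and a step that the two limits leave unreadable from compound 2 to compound 3 are both unreadable, as is a step that the two limits leave unreadable from compound 1 to compound 2; two values sit at the limit of > 10 mg/kg in this assay, at which 2 of the 3 values shown sit, and one at the limit of > 8 mg/kg in this assay, at which 1 of the 3 values shown sits.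

Compound 4 `COc1cc(N)c(Cl)cc1NC(=O)C1CCN(Cc2cccc(Cl)c2)CC1` is to be measured in this assay. The change is 3-chlorophenyl in place of 4-hydroxyphenyl on a saturated chain carbon bound to an amine nitrogen in a ring. For the measured compounds named here, every step among compounds 1, 2 and 3 is bounded by limits on both sides, and no measured step bears readably on this change. The expectation is that compound 4 remains in the region of the limits seen so far, with a step that the limit leaves unreadable from compound 3 to compound 4 expected to be small or unreadable. Compound 4 is estimated at 15 mg/kg, within 5 mg/kg to 50 mg/kg, with a fair chance that only a limit is reported.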

Compound 4, dose for half-maximal effect: > 4 mg/kg
Compound 4 was reported as a limit; the forecaster's own chance of this, stated with the estimate: 70%; the middle value is on the limit's open side.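

In this assay compound 4 gives only a limit, > 4 mg/kg. With compound 1, compound 2 and compound 3 also standing as limits, none of the steps to compound 4 can be read. The compounds shown leave open whether any of these groups gives a dose for half-maximal effect that can be read as a number, and how the four groups rank.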